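The source may hold more compounds than are shown below. What is called first, only, known or untested is meant among the compounds shown, and "the series" means these compounds.

Measured so far in a functional assay on the whole organism (Ehrlich cells) with Mus musculus as the target, at a dose of 50 mg/kg by the intraperitoneal route; on this read-out lower numbers stand for less inhibition and higher numbers for more inhibition at the one dose given (going by the name of the read-out):
compound 1 `Cc1ccc(S(=O)(=O)N2C(=O)CCC2C(=O)NNc2ccccc2)cc1` — 77.6%
compound 2 `O=C(NNc1ccccc1)C1CCC(=O)N1S(=O)(=O)c1ccc(Cl)cc1` — 74.3%

Compound 2 is one of two measured compounds, and its value lies within the scatter of that of compound 1, so no order between the two can be read from the numbers. For the measured compounds named here, the only measured step is a number 3.3 percentage points lower from compound 1 to compound 2 (within the scatter), a change that did not move the read-out beyond the scatter.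

Compound 3 `O=C(NNc1ccccc1)C1CCC(=O)N1S(=O)(=O)c1ccc(Cl)c(Cl)c1` is not yet measured. It differs from compound 2 by chloro in place of hydrogen on an aromatic carbon, placed on an aromatic carbon of a six-membered aromatic ring of carbon only, ortho to a chloro group and meta to a large group; read one bond further out, 4-chlorophenyl becomes 3,4-dichlorophenyl.

Going by the values given here, the one step that bears on this change, the swap of methyl for chloro on the same ring between compound 1 and compound 2, was within the scatter. A second chloro on that ring is therefore expected to give no step beyond the scatter, a number 1.3 percentage points lower from compound 2 to compound 3 (within the scatter). For compound 3 the estimate in this assay is 73%, expected within 60% to 84%.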

Compound 3, a percentage reported as inhibition, in the whole organism at one dose (the size of the read-out at that dose, not a potency): 66.9%
Beside the measured number, compound 3's estimate is 6.1 percentage points above it; low and high end bracket the measured number.
By their numbers in this assay, from the lowest: compounds 3, 2 and 1 (each within the scatter of the next, the first and the last beyond it).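

In this assay the second chloro, ortho to a chloro group on the aromatic ring, gives a number 7.4 percentage points lower from compound 2 to compound 3 (within the scatter) and so, as a single change, does not separate the two compounds. Set against 4-methylphenyl on the sulfonyl sulfur, however, 3,4-dichlorophenyl gives a number 10.7 percentage points lower from compound 1 to compound 3 (beyond the scatter) and is the first step in the series to pass the scatter, though it is modest, which shows that changes on this ring can add up to a readable difference at the one dose given. No measured evidence bears on the reason for either step.

Only methyl and chloro are shown on this ring, so it remains open whether a methoxy group, an amine or a carboxylic acid in the same place would give a step beyond the scatter. From the compounds shown here alone, the other phenyl ring is the same in all three compounds, so the outcome of placing a chloro or a methoxy group there also remains open, as does how these compounds would compare at any other dose.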